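The compounds below may be only part of what the source reports. "The series", "measured", "known", "first", "only" and "open" are said of these compounds alone.

Compound 2 `CCc1ccc(S(=O)(=O)Nc2ccc(-c3nc4ccccc4o3)cc2)cc1` stands at the limit of an assay on cells for inhibition of HSP60/HSP10 (Homo sapiens), with a stated time of 60 min; a lower number here means a stronger inhibitor, a higher number a weaker inhibitor: in this assay compound 2 gives > 100000 nM, which is a limit and not a number. Compound 1 `O=S(=O)(Nc1ccc(-c2nc3ccccc3o2)cc1)c1ccccc1F` likewise gives only a limit in this assay, > 100000 nM. The step that the two limits leave unreadable from compound 1 to compound 2 therefore cannot be read; both values sit at the limit of > 100000 nM in this assay, at which 2 of the 2 values shown sit. Compound 3 `COc1cccc(S(=O)(=O)Nc2ccc(-c3nc4ccccc4o3)cc2)c1` differs from compound 2 by 3-methoxyphenyl in place of 4-ethylphenyl on a sulfonyl sulfur. Going by the values given here, no measured step with a readable size bears on this change. The expected step that the limit leaves unreadable from compound 2 to compound 3 is itself unreadable, with a limit again the likeliest outcome. Compound 3 is estimated at 150000 nM, ranging from 40000 nM to 600000 nM.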

Compound 3, half-maximal inhibitory concentration: 80000 nM
The estimate for compound 3 lay 1.9-fold (0.27 log units) above the measured number; measured number inside the range.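

In this assay, compound 3 is the only compound shown with a number and not a limit, so this position on the sulfonyl sulfur now has one readable value. Setting 3-methoxyphenyl in place of 4-ethylphenyl gives an at least 1.2-fold lower number from compound 2 to compound 3 (0.09 log units; that floor lies within the scatter), and setting it in place of 2-fluorophenyl gives an at least 1.2-fold lower number from compound 1 to compound 3 (0.09 log units; that floor lies within the scatter); both are floors, so the true size of the change stays unknown. The other two compounds remain at the limit: the limit of > 100000 nM in this assay, at which 2 of the 3 values shown sit.

Open, on these data alone, is whether 4-methoxyphenyl would read as 3-methoxyphenyl does in this assay. Also open, as far as these compounds go, is how a phenyl bearing an amine or a carboxylic acid would read at this position.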